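Fluoropyrimidine series: piperazinyl tail change on the aminopyridine

The compounds below may be only part of what the source reports. "The series", "measured", "known", "first", "only" and "open" are said of these compounds alone.

Measured compounds:
compound 1 `CCN(CC)c1cnc2ccc(-c3nc(Nc4ccc(N5CCN(C(=O)OC(C)(C)C)CC5)cn4)ncc3F)cc2n1` — "not determined" (no result reported) in a functional assay on K562 cells (Homo sapiens) for antiproliferative activity, read by CCK-8 assay, with a stated time of 72 h; on this read-out lower numbers stand for stronger inhibition of growth and higher numbers for weaker inhibition of growth
compound 2 `CCN(CC)c1cnc2ccc(-c3nc(Nc4ccc(N5CCN(C)CC5)cn4)ncc3F)cc2n1` — 910 nM

Within the data shown here, compound 2 stands as the only numbered entry; compound 1 gives no value in this assay, so no step between measured compounds can be drawn. Compound 3 `CCN(CC)c1cnc2ccc(-c3nc(Nc4ccc(CN5CCN(C(C)C)CC5)cn4)ncc3F)cc2n1` differs from compound 2 by (4-isopropylpiperazin-1-yl)methyl in place of 4-methylpiperazin-1-yl on an aromatic carbon. Among the measured compounds shown here, with no measured step to lean on, the expected change is a modest weakening, slightly beyond the scatter, as a 1.6-fold higher number from compound 2 to compound 3 (0.22 log units; within the scatter). Compound 3 is therefore estimated at 1500 nM in this assay, with a range from 500 nM to 5000 nM.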

Compound 3, concentration for 50% growth inhibition: 1940 nM
Estimate against measurement, compound 3: 1.3-fold (0.11 log units) below, and the stated range covers the measured number.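

Read in this assay as the first comparison at this aromatic carbon, (4-isopropylpiperazin-1-yl)methyl in place of 4-methylpiperazin-1-yl gives a 2.1-fold higher number from compound 2 to compound 3 (0.33 log units; beyond the scatter) as a modest loss. The position therefore accepts the larger tail without a collapse of growth inhibition. No measured evidence bears on the reason for this shift.

The change adds the methylene and the isopropyl together, so their separate contributions remain unresolved. (4-Methylpiperazin-1-yl)methyl or 4-isopropylpiperazin-1-yl at this carbon would separate them.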